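This account rests on a few compounds, and the source may have more. Where it says the series, first, only, none or still open, it means among the compounds named here.

Working notes on the series. Of the compounds shown here, two on the shared core have been measured in a functional assay on MGC-803 cells (Homo sapiens) for antiproliferative activity, read by CCK-8 assay, with a stated time of 72 h; on this read-out higher numbers stand for weaker inhibition and lower numbers for stronger inhibition. Compound 1 `CC(=O)N1CC=C(c2ccn3c(-c4ccc(NC(=O)c5ccc([N+](=O)[O-])o5)cc4)cnc3c2)CC1` gives 940 nM. Among the compounds with values here, compound 2 `CN1CCCN(c2ccn3c(-c4ccc(NC(=O)c5ccc([N+](=O)[O-])o5)cc4)cnc3c2)CC1` gives 3580 nM, the highest number of the two; the only measured step, a 3.8-fold higher number from compound 1 to compound 2 (0.58 log units; beyond the scatter), exchanges one ring group for another at the same aromatic carbon and is the sole indication of how this position responds.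

Compound 3 `O=C(Nc1ccc(-c2cnc3cc(Br)ccn23)cc1)c1ccc([N+](=O)[O-])o1` differs from compound 2 in one place: bromo in place of 4-methyl-1,4-diazepan-1-yl on an aromatic carbon. Within the data shown here, the step from compound 1 to compound 2 bears on it insofar as it concerns the same position on the core, but neither measured compound carries a single-atom substituent there, so no measured step tells the direction of removing the ring group altogether. Among the measured compounds shown here, the one step shows that this position can move the number by a modest amount, so a modest step in this assay in either direction cannot be excluded, and the estimate is placed between the two measured numbers.

Compound 3 is therefore estimated at 1500 nM, with a range of 400 nM to 6000 nM; the expected step is a 2.4-fold lower number from compound 2 to compound 3 (0.38 log units; beyond the scatter).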

Compound 3, half-maximal inhibitory concentration: 750 nM
Estimate against measurement, compound 3: 2.0-fold (0.30 log units) above; the range from low to high includes it.
By their numbers in this assay, from the lowest: compounds 3 and 1 (each within the scatter of the next); then compound 2.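

Bromo in place of 4-methyl-1,4-diazepan-1-yl in this assay gives a 4.8-fold lower number from compound 2 to compound 3 (0.68 log units; beyond the scatter), which shows that this aromatic carbon needs no ring group for a number at the lower end of the series and that the step from the diazepane to a single atom is larger than the one step known before. The change from the ring group of compound 1 to one bromine atom gives a 1.3-fold lower number from compound 1 to compound 3 (0.10 log units; within the scatter), which lies within the scatter, so this assay does not separate a group of that size from a single bromine atom at this position, and only compound 2 stands apart. No measurement here accounts for these differences between the groups.

On these data alone, it remains open whether the number of compound 3 depends on bromine itself or only on the absence of the 4-methyl-1,4-diazepan-1-yl group, a question that chloro, plain hydrogen or a small open-chain amine such as dimethylamino on this carbon would address. Also open, as far as these compounds go, is how a carboxylic acid or a longer alkyl chain at this position would read in this assay.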